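The source may hold more compounds than are shown below. What is called first, only, known or untested is meant among the compounds shown, and "the series" means these compounds.

In a functional assay, with a stated time of 6 min (on this read-out higher numbers stand for weaker inhibition and lower numbers for stronger inhibition), compound 1 `COc1ccc(NCn2nc(-c3ccc4c(c3)OCCO4)oc2=S)cc1` gives 5830 nM and compound 2 `FC(F)(F)c1cccc(NCn2nc(-c3ccc4c(c3)OCCO4)oc2=S)c1` gives 7620 nM. These two numbers lie within the scatter of each other, so compound 2 cannot be separated from compound 1 on the present data. Compound 3 `S=c1oc(-c2ccc3c(c2)OCCO3)nn1CNc1cccc(Br)c1` has not yet been measured. It differs from compound 2 by bromo in place of trifluoromethyl on an aromatic carbon, with bromo in place of trifluoromethyl on an aromatic carbon. Among the measured compounds shown here, no measured pair differs in one place only, so this change has no direct precedent. The expectation rests only on the closeness of compound 1 at 5830 nM and compound 2 at 7620 nM, and no step beyond the scatter is expected in this assay. The expected change is a 1.3-fold lower number from compound 2 to compound 3 (0.10 log units; within the scatter). For compound 3 the estimated value is 6000 nM, with an expected range from 2500 nM to 15000 nM.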

Compound 3, half-maximal inhibitory concentration: 10800 nM
For compound 3 the middle estimate is 1.8-fold (0.26 log units) below the measured one; the range from low to high includes it.
By their numbers in this assay, from the lowest: compounds 1, 2 and 3 (each within the scatter of the next).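

In this assay, among the compounds shown here, bromo in place of trifluoromethyl on an aromatic carbon, meta to a large group, gives a 1.4-fold higher number from compound 2 to compound 3 (0.15 log units; within the scatter) and so leaves no separable effect at this position, the first direct reading of a change at this place. Exchange of the whole aryl group, 3-bromophenyl in place of 4-methoxyphenyl on an amine nitrogen, gives a 1.9-fold higher number from compound 1 to compound 3 (0.27 log units; within the scatter) and so also cannot be told apart on these data. No measurement on these compounds offers an explanation for either step.

As far as these compounds go, whether any group at this aromatic carbon can move the number beyond the scatter remains open, since bromo and trifluoromethyl do not separate. A carboxylic acid or an amine there, or a plain hydrogen in place of bromo, would test this.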